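The source may report more compounds than this note shows. Statements on the series, on what has been measured and on what is new or still open speak of the compounds shown alone.

Measured so far in a functional assay on HepG2 cells (Homo sapiens) for cytotoxicity, read by MTT assay, with a stated time of 24 h; a lower number here means a stronger inhibitor, a higher number a weaker inhibitor: compound 1 `CC(=O)Nc1ccc(S(=O)(=O)N2C/C(=C\c3ccc(C#N)cc3)C(=O)/C(=C/c3ccccc3F)C2)cc1` with 4960 nM; compound 2 `COc1cc(/C=C2\CN(S(=O)(=O)c3ccc(NC(C)=O)cc3)C/C(=C\c3ccccc3F)C2=O)cc(OC)c1` with 6800 nM; compound 3 `COc1cc(/C=C2\CN(S(=O)(=O)c3ccc(NC(C)=O)cc3)C/C(=C\c3ccc(C#N)cc3)C2=O)cc(OC)c1OC` with 2890 nM.

Compound 4 `COc1cc(/C=C2\CN(S(=O)(=O)c3ccc(NC(C)=O)cc3)C/C(=C\c3cc(OC)c(OC)c(OC)c3)C2=O)cc(OC)c1` has not yet been measured in this assay. It differs from compound 3 in one place: 3,5-dimethoxyphenyl in place of 4-cyanophenyl on a double-bonded chain carbon bound to a double-bonded ring carbon. The same change, (3,5-dimethoxyphenyl in place of 4-cyanophenyl on a double-bonded chain carbon bound to a double-bonded ring carbon), was made between two measured compounds, and there it produced a 1.4-fold higher number from compound 1 to compound 2 (0.14 log units; within the scatter). The two cores on which the change is made are not identical: the core of compound 3 differs from the core of compound 1 by 3,4,5-trimethoxyphenyl in place of 2-fluorophenyl on a double-bonded chain carbon bound to a double-bonded ring carbon, a difference that on its own gave a 1.7-fold lower number from compound 1 to compound 3 (0.23 log units; within the scatter). Since the place of the change reads the same in both pairs, the step from compound 3 to compound 4 is the same change on a different core. Compound 3 stands at the lowest number of the three, with compound 1 within the scatter of it and compound 2 beyond it.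

From compound 3 to compound 4 a step of a 1.4-fold higher number from compound 3 to compound 4 (0.14 log units; within the scatter) is expected in this assay, resting on the earlier step of a 1.4-fold higher number from compound 1 to compound 2 (0.14 log units; within the scatter). Compound 4 is therefore estimated at 4000 nM, plausibly between 2000 nM and 8000 nM.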

Compound 4, half-maximal inhibitory concentration: 4140 nM
Compound 4: middle estimate off by 1.0-fold (0.01 log units), on the low side; low and high end bracket the measured number.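

In this assay, 3,5-dimethoxyphenyl in place of 4-cyanophenyl gives a 1.4-fold higher number from compound 3 to compound 4 (0.16 log units; within the scatter), and this matches the step seen on the core of compound 1: the same change on two cores in this assay, a 1.4-fold higher number (0.14 log units; within the scatter) from compound 1 to compound 2 and a 1.4-fold higher number (0.16 log units; within the scatter) from compound 3 to compound 4, 1.0-fold (0.02 log units) apart, within the scatter of two such steps. The swap of 2-fluorophenyl for 3,4,5-trimethoxyphenyl, which gives a 1.6-fold lower number from compound 2 to compound 4 (0.22 log units; within the scatter), also carries over from one core to the other: the same change on two cores in this assay, a 1.7-fold lower number (0.23 log units; within the scatter) from compound 1 to compound 3 and a 1.6-fold lower number (0.22 log units; within the scatter) from compound 2 to compound 4, 1.0-fold (0.02 log units) apart, within the scatter of two such steps. The two changes therefore kept their size on both cores among these four compounds, but every step lies within the scatter, so this does not show that either change truly moves the number, nor that the agreement would hold on other cores or for larger steps.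

The compounds shown leave open how an amine or a carboxylic acid in place of these aryl groups, on a double-bonded chain carbon bound to a double-bonded ring carbon, would read in this assay. Going by these compounds, a longer chain at that place remains equally open.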